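The source may report more compounds than this note shows. Statements on the series, on what has been measured and on what is new or still open speak of the compounds shown alone.

Measured compounds:
- compound 1 `COc1cc(/C=C2\CN(S(=O)(=O)c3ccc(NC(C)=O)cc3)C/C(=C\c3cc(OC)c(OC)c(OC)c3)C2=O)cc(OC)c1OC`: 1900 nM
- compound 2 `COc1cc(/C=C2\CN(S(=O)(=O)c3ccc(F)cc3)C/C(=C\c3cc(OC)c(OC)c(OC)c3)C2=O)cc(OC)c1`: 5200 nM
- compound 3 `COc1cc(/C=C2\CN(S(=O)(=O)c3ccc(NC(C)=O)cc3)C/C(=C\c3cccc([N+](=O)[O-])c3)C2=O)cc(OC)c1OC`: 2550 nM

In a functional assay on QGY-7703 cells (Homo sapiens) for cytotoxicity, read by MTT assay, with a stated time of 24 h (on this read-out lower numbers stand for stronger inhibition and higher numbers for weaker inhibition), compound 3 gives 2550 nM, within the scatter of compound 1 at 1900 nM. Its value lies beyond the scatter from that of compound 2, which has the higher number at 5200 nM.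

Compound 4 `COc1cc(/C=C2\CN(S(=O)(=O)c3ccc(NC(C)=O)cc3)C/C(=C\c3cc(OC)c(OC)c(OC)c3)C2=O)cc(OC)c1` has 3,5-dimethoxyphenyl in place of 3-nitrophenyl on a double-bonded chain carbon bound to a double-bonded ring carbon. Among the compounds with values here, the one measured step at this place is a 1.3-fold higher number from compound 1 to compound 3 (0.13 log units; within the scatter), and it stays within the scatter. Compound 4 also shares 3,5-dimethoxyphenyl with compound 2 at 5200 nM, but the two differ elsewhere, so that value is only a weak hint towards a higher number.

In this assay no change beyond the scatter is therefore expected, and the estimated step is a 1.1-fold higher number from compound 3 to compound 4 (0.02 log units; within the scatter). The estimate for compound 4 is 2700 nM, with an expected range from 1300 nM to 5600 nM.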

Compound 4, half-maximal inhibitory concentration: 2020 nM
The estimate for compound 4 lay 1.3-fold (0.13 log units) above the measured number, and the stated range covers the measured number.
By their numbers in this assay, from the lowest: compounds 1, 4 and 3 (each within the scatter of the next); then compound 2.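

In this assay, 3,5-dimethoxyphenyl in place of 3-nitrophenyl on a double-bonded chain carbon bound to a double-bonded ring carbon gives a 1.3-fold lower number from compound 3 to compound 4 (0.10 log units; within the scatter) and stays within the scatter, while hydrogen in place of methoxy on an aromatic carbon gives a 1.1-fold higher number from compound 1 to compound 4 (0.03 log units; within the scatter) and also stays within it, so 3-nitrophenyl, 3,5-dimethoxyphenyl and 3,4,5-trimethoxyphenyl are not told apart at this place. Within the data shown here, the first single-place step beyond the scatter, acetamido in place of fluoro on an aromatic carbon, gives a 2.6-fold lower number from compound 2 to compound 4 (0.41 log units; beyond the scatter) and lies away from this place. No measurement shown offers a reason for either result.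

As far as these compounds go, whether an amine or a carboxylic acid on this phenyl ring would also stay within the scatter remains open. From the compounds shown here alone, a single pair carries the acetamido and fluoro change, so whether it holds with 3-nitrophenyl or 3,4,5-trimethoxyphenyl at this place is also open.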